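Sulfonyl aryl exchange in the coumarin-triazole sulfonamide series

The source may report more compounds than this note shows. Statements on the series, on what has been measured and on what is new or still open speak of the compounds shown alone.

Measured so far in a functional assay on HepG2 cells (Homo sapiens) for inhibition, read by MTT assay, with a stated time of 72 h; a higher number here means a weaker inhibitor, a lower number a stronger inhibitor:
- compound 1 `CC(C)(C)c1cn(Cc2cc(=O)oc3cc(O)ccc23)nn1` gives > 100000 nM, which is a limit of this assay and not a number
- compound 2 `O=c1cc(Cn2cc(CCc3ccccc3)nn2)c2ccc(O)cc2o1` gives 50500 nM
- compound 3 `Cc1ccc(S(=O)(=O)NCc2cn(Cc3cc(=O)oc4cc(O)ccc34)nn2)cc1` gives 29800 nM

Compound 3 holds the lowest of the two numbers, but compound 2 sits within the scatter of it, so the two cannot be ordered. Compound 1 is reported only as a limit (the limit of > 100000 nM in this assay, at which 1 of the 3 values shown sits). For the measured compounds named here, the single measured step, an at least 1.9-fold lower number from compound 1 to compound 2 (0.29 log units; that floor lies within the scatter), concerns the group on an aromatic carbon and is itself at a floor within the scatter; it does not touch the sulfonamide part.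

Compound 4 `O=c1cc(Cn2cc(CNS(=O)(=O)c3ccc(F)cc3Cl)nn2)c2ccc(O)cc2o1` differs from compound 3 by 2-chloro-4-fluorophenyl in place of 4-methylphenyl on a sulfonyl sulfur. Going by the values given here, no measured step in this set alters the aryl on the sulfonyl sulfur, so there is nothing to point to a change beyond the scatter. The step from compound 3 to compound 4 is therefore expected to be small, a 1.0-fold higher number from compound 3 to compound 4 (0.00 log units; within the scatter). For compound 4 the estimate in this assay is 30000 nM, with a range from 10000 nM to 100000 nM.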

Compound 4, half-maximal inhibitory concentration: 74800 nM
The estimate for compound 4 lay 2.5-fold (0.40 log units) below the measured number; measured number inside the range.
By their numbers in this assay, from the lowest: compounds 3, 2 and 4 (each within the scatter of the next, the first and the last beyond it). At a limit, above all of these: compound 1.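

For the compounds shown here, the aryl on the sulfonyl sulfur is the first place where a single exchange gives a step beyond the scatter in this assay: a 2.5-fold higher number from compound 3 to compound 4 (0.40 log units; beyond the scatter). This place is therefore not indifferent to the aryl, even though both groups are a six-membered aromatic ring of carbon only, and 2-chloro-4-fluorophenyl gives the weaker inhibitor of the pair. Nothing at hand bears on the reason for this step.

Going by these compounds, the exchange removes the methyl and brings in chlorine and fluorine together, so it remains open whether either halogen alone would give the same step. Also open, on these data alone, is how a plain phenyl, or an amine or a carboxylic acid on that ring, would read in this assay.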